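Moving a phenol hydroxyl along the styryl arm

The source may hold more compounds than are shown below. What is called first, only, known or untested is meant among the compounds shown, and "the series" means these compounds.

Compound 2 `Oc1cccc(/C=C/C[C@H]2C[C@@H]([C@@H](O)c3ccccc3)CO[C@@H]2c2ccccc2)c1` is one of three compounds with a result in a functional assay on HL-60 cells (Homo sapiens) for cytotoxicity, read by WST assay, with a stated time of 48 h; on this read-out higher numbers stand for weaker inhibition and lower numbers for stronger inhibition. In this assay compound 2 gives 12800 nM, the lowest of the two numbers seen so far. Its nearest neighbour is compound 1 `COc1ccc(/C=C/C[C@@H]2C[C@@H]([C@@H](O)c3ccc(OC)c(OC)c3)CO[C@H]2c2ccc(OC)c(OC)c2)cc1OC`, which in this assay gives 26000 nM, a gap that lies beyond the usual scatter. Compound 3 `COc1ccc(/C=C/C[C@@H]2C[C@H]([C@H](O)c3ccc(OC)c(OC)c3)CO[C@H]2c2ccc(OC)c(OC)c2)cc1OC` has no result reported in this assay, where its entry reads "not determined" (no result reported); it differs from compound 1 only in the configuration as drawn (the fact that compounds 1 and 3 differ only in the configuration as drawn).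

Compound 4 `Oc1ccc(/C=C/C[C@H]2C[C@@H]([C@@H](O)c3ccccc3)CO[C@@H]2c2ccccc2)cc1` is the one still to be measured. It is built from compound 2 with a single change: 4-hydroxyphenyl in place of 3-hydroxyphenyl on a double-bonded chain carbon bound to a double-bonded chain carbon. Among the compounds with values here, no measured pair in this set shows what such a shift of the hydroxyl does, so there is no step to lean on. The expectation is therefore a step of no clear size in either direction, nothing beyond the scatter, which the estimate states as no change at the digits printed from compound 2 to compound 4 (within the scatter). Compound 4 is thus expected to give about 12800 nM in this assay, within a range from 4000 nM to 40000 nM.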

Compound 4, half-maximal inhibitory concentration: 7380 nM
For compound 4 the middle estimate is 1.7-fold (0.24 log units) above the measured one; the measured number falls inside the stated range.
By their numbers in this assay, from the lowest: compounds 4 and 2 (each within the scatter of the next); then compound 1.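

Within the data shown here, this is the first pair in the set that differs in one place only, and so the first direct look at where the hydroxyl sits on the styryl arm. In this assay, 4-hydroxyphenyl in place of 3-hydroxyphenyl on a double-bonded chain carbon bound to a double-bonded chain carbon gives a 1.7-fold lower number from compound 2 to compound 4 (0.24 log units; within the scatter), so this assay does not tell these two placements apart. Nothing known about these compounds bears on this result.

Whether the hydroxyl is needed at all remains open, since the compounds shown do not tell what a plain phenyl, an amine or a carboxylic acid would do on this arm. Compound 1 differs from compound 4 in more than one place, so it cannot settle that question.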